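Cytotoxicity of Halogenated Phenyl Semicarbazones on Fibroblasts

The source may report more compounds than this note shows. Statements on the series, on what has been measured and on what is new or still open speak of the compounds shown alone.

Compound 2 `COc1cc(/C=N/NC(=O)Nc2ccc(Oc3ccnc(-c4nncn4CCN(C)C)c3)c(F)c2)cc(OC)c1OC` carries a 3,4,5-trimethoxyphenyl group on the carbon with a double bond to nitrogen. In an ADME assay on WI-38 cells (Homo sapiens) for cytotoxicity, read by MTT assay, with a stated time of 72 h (a lower number here means a stronger inhibitor, a higher number a weaker inhibitor), compound 2 gives "not determined" (no result reported), so no single number stands for it. Within the data shown here, the only measured point is compound 1 `CN(C)CCn1cnnc1-c1cc(Oc2ccc(NC(=O)N/N=C/c3ccc(Cl)cc3Cl)cc2F)ccn1`, which bears a different halogenated phenyl group on that same carbon, and in this assay compound 1 gives 4760 nM. Compound 3 `CN(C)CCn1cnnc1-c1cc(Oc2ccc(NC(=O)N/N=C/c3cccc(Br)c3)cc2F)ccn1` differs from compound 2 in one place: 3-bromophenyl in place of 3,4,5-trimethoxyphenyl on a carbon with a double bond to nitrogen. Among the measured compounds shown here, no step from compound 2 can be measured, and compound 1 is the only anchor available. Compound 3 is expected to fall within the scatter of the value of compound 1 in this assay, 4760 nM, with no step beyond the scatter in either direction. Compound 3 is therefore estimated at 5000 nM in this assay, with a range from 1500 nM to 16000 nM.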

Compound 3, half-maximal inhibitory concentration: 4230 nM
Compound 3: middle estimate off by 1.2-fold (0.07 log units), on the high side; the measured number falls inside the stated range.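

In this assay, putting 3-bromophenyl in place of 2,4-dichlorophenyl on a carbon with a double bond to nitrogen gives a 1.1-fold lower number from compound 1 to compound 3 (0.05 log units; within the scatter) and so stays inside the usual scatter. This position, which had only one measured point before, now has two, and they show that this exchange of one halogenated phenyl group for another does not separate the two compounds in this read-out. No measurement at hand bears on the reason for this result.

Steps from compound 2 cannot be read, so it stays open whether 3,4,5-trimethoxyphenyl at this place would read like the two halogenated phenyl groups. Also open, as far as these compounds go, is how a phenyl group carrying an amine or a carboxylic acid in place of the halogen would read in this assay.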